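The compounds below may be only part of what the source reports. "The series", "measured", "known", "first", "only" and "open" are said of these compounds alone.

Compound 1 `O=C(CN(c1nc(Cl)nc2[nH]cnc12)C1CC1)N[C@@H](CO)C(=O)O` in a functional assay on the whole organism (Tail, strain ICR) with Mus musculus as the target, in the tail flick test, with a stated time of 90 min, at a dose of 25 umol/kg by the oral route (on this read-out lower numbers stand for a weaker effect and higher numbers for a stronger effect at the one dose given), gives 43.9%. Compound 2 `O=C(O)CNC(=O)CN(c1nc(Cl)nc2[nH]cnc12)C1CC1` gives 32.3%. Compound 3 `CC(C)[C@H](NC(=O)CN(c1nc(Cl)nc2[nH]cnc12)C1CC1)C(=O)O` gives 30.3%.

Compound 3 has the lowest of the three numbers, but its gap to compound 2 lies within the scatter, while compound 1 stands above it beyond the scatter. Compound 4 `NC(=O)CC[C@H](NC(=O)CN(c1nc(Cl)nc2[nH]cnc12)C1CC1)C(=O)O` differs from compound 3 by 2-carbamoylethyl in place of isopropyl on a saturated chain carbon bound to an amide-type nitrogen and a carbonyl carbon. Among the compounds with values here, two measured steps bear on this place. The step of a number 13.6 percentage points lower from compound 1 to compound 3 (beyond the scatter) traded a hydroxymethyl for the isopropyl; the step of a number 2 percentage points lower from compound 2 to compound 3 (within the scatter) traded a hydrogen for it. The entering 2-carbamoylethyl, like hydroxymethyl, brings one hydrogen-bond donor and one acceptor, so a partial return toward compound 1 is expected, a rise of a number 7.7 percentage points higher from compound 3 to compound 4 (within the scatter). Compound 4 is estimated at 38%, between 24% and 52%.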

Compound 4, a percentage reported as activity, at one dose (the size of the read-out at that dose, not a potency): 41.1%
Beside the measured number, compound 4's estimate is 3.1 percentage points below it; the measured number falls inside the stated range.
By their numbers in this assay, from the lowest: compounds 3, 2, 4 and 1 (each within the scatter of the next, the first and the last beyond it).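

In this assay, 2-carbamoylethyl in place of isopropyl gives a number 10.8 percentage points higher from compound 3 to compound 4 (beyond the scatter) so a side chain other than hydroxymethyl can also carry a higher number at this place. Set against a plain hydrogen, the same group gives a number 8.8 percentage points higher from compound 2 to compound 4 (within the scatter) and set against the hydroxymethyl side chain, the change gives a number 2.8 percentage points lower from compound 1 to compound 4 (within the scatter) so neither of these two gaps can be told apart from the scatter. Nothing measured here explains these differences. Still open, from the compounds shown here alone, is whether a carboxylic acid, an amine or a longer chain at this place would give a number like that of compound 1 or that of compound 3.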